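The source may report more compounds than this note shows. Statements on the series, on what has been measured and on what is new or still open speak of the compounds shown alone.

Measured so far in a functional assay on MCF7 cells (Homo sapiens) for inhibition, read by CCK-8 assay, with a stated time of 48 h; on this read-out lower numbers stand for stronger inhibition and higher numbers for weaker inhibition:
- compound 1 `COc1cc(-c2ccnc3cc(-c4ccccc4)nn23)cc(OC)c1OC` at 254 nM
- compound 2 `COc1cc(-c2ccnc3cc(-c4ccc5c(ccn5C)c4)nn23)cc(OC)c1OC` at 3 nM
- compound 3 `COc1cc(-c2ccnc3cc(-c4ccc5cc[nH]c5c4)nn23)cc(OC)c1OC` at 23 nM

Compound 3 stands in the middle of these three numbers. Its gap on one side is an 11-fold lower number from compound 1 to compound 3 (1.04 log units; beyond the scatter) and its gap on the other is a 7.7-fold higher number from compound 2 to compound 3 (0.88 log units; beyond the scatter) and both lie beyond the scatter.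

Compound 4 `COc1cc(-c2ccnc3cc(-c4cccc(C)c4)nn23)cc(OC)c1OC` differs from compound 3 by 3-methylphenyl in place of 1H-indol-6-yl on an aromatic carbon and so carries 3-methylphenyl in place of 1H-indol-6-yl on an aromatic carbon of the shared core. Going by the values given here, no measured step isolates the methyl group. The closest guide is compound 1, which also has a single six-membered aromatic ring of carbon only. The large steps of an 11-fold lower number from compound 1 to compound 3 (1.04 log units; beyond the scatter) and an 85-fold lower number from compound 1 to compound 2 (1.93 log units; beyond the scatter) show how far the number moves when an indolyl group replaces phenyl, and the change to compound 4 is expected to give back most of the first of these. The methyl group may leave compound 4 somewhat lower than compound 1, but the data do not show this. In this assay a modest rise is therefore expected, estimated as a 5.2-fold higher number from compound 3 to compound 4 (0.72 log units; beyond the scatter) for this change. Compound 4 is estimated at 120 nM with an expected range from 35 nM to 400 nM in this read-out.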

Compound 4, half-maximal inhibitory concentration: 1080 nM
Estimate against measurement, compound 4: 9.0-fold (0.95 log units) below; the measured number lies above the stated range.
By their numbers in this assay, from the lowest: compound 2; then compound 3; then compound 1; then compound 4.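

In this assay, going by these compounds alone, the first direct look at a substituent on the single phenyl ring at this position shows that methyl in place of hydrogen does not bring the number down, as it gives a 4.3-fold higher number from compound 1 to compound 4 (0.63 log units; beyond the scatter). Set against the indolyl compounds, 3-methylphenyl stands far higher, with a 47-fold higher number from compound 3 to compound 4 (1.67 log units; beyond the scatter) and a 360-fold higher number from compound 2 to compound 4 (2.56 log units; beyond the scatter), so among the four compounds both indolyl groups give lower numbers than both single-ring groups, and no compound goes against this. Nothing at hand bears on why the number moves in this way.

The compounds shown leave open whether an amine or a methoxy group in place of the methyl on the phenyl ring would also raise the number, or would instead bring it closer to the indolyl compounds. They also leave open how much of the gap between compound 2 and compound 3 belongs to the methyl on the indole nitrogen and how much to the point at which the indolyl group is attached, since those two features change together in that pair.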